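This account rests on a few compounds, and the source may have more. Where it says the series, first, only, none or still open, it means among the compounds named here.

Compound 1, with the structure `CC(=O)OCCC(=O)O[C@H](CC=C(C)C)C1=CC(=O)c2c(O)ccc(O)c2C1=O`, is one of three analogues sharing the same core that differ only in the acyl group on the side-chain oxygen. In a functional assay on DU-145 cells (Homo sapiens) for cytotoxicity, read by MTT assay (on this read-out lower numbers stand for stronger inhibition and higher numbers for weaker inhibition), compound 1 gives 15700 nM. Of the three numbers recorded so far this is the second highest, but the steps to both neighbours are within the scatter: compound 2, `CCC(C)(O)CC(=O)O[C@H](CC=C(C)C)C1=CC(=O)c2c(O)ccc(O)c2C1=O`, gives 16000 nM, and compound 3, `CC(C)=CC[C@@H](OC(=O)C1CCCO1)C1=CC(=O)c2c(O)ccc(O)c2C1=O`, gives 10500 nM. The three measured steps are a 1.0-fold higher number from compound 1 to compound 2 (0.01 log units; within the scatter), a 1.5-fold lower number from compound 1 to compound 3 (0.17 log units; within the scatter) and a 1.5-fold lower number from compound 2 to compound 3 (0.18 log units; within the scatter), none of them beyond the scatter.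

Compound 4, `CCC(O)(CC)CC(=O)O[C@H](CC=C(C)C)C1=CC(=O)c2c(O)ccc(O)c2C1=O`, has not yet been measured. Relative to compound 1 the change is 1-ethyl-1-hydroxypropyl in place of acetoxymethyl on a saturated chain carbon bound to a carbonyl carbon. The step that bears most directly on it is the one in which a hydroxylated group likewise replaced acetoxymethyl at the same place, namely a 1.0-fold higher number from compound 1 to compound 2 (0.01 log units; within the scatter), which was within the scatter; the other two steps, touching the carbonyl carbon, were within the scatter as well. On this basis no step beyond the scatter is expected in this assay, in either direction, and the expected step is a 1.0-fold lower number from compound 1 to compound 4 (0.02 log units; within the scatter). Compound 4 is therefore estimated to give 15000 nM, within a range from 7000 nM to 32000 nM.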

Compound 4, half-maximal inhibitory concentration: 67000 nM
For compound 4 the middle estimate is 4.5-fold (0.65 log units) below the measured one; the whole stated range lies below it.
By their numbers in this assay, from the lowest: compounds 3, 1 and 2 (each within the scatter of the next); then compound 4.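

In this assay, within the data shown here, the acyl group on the side-chain oxygen turns out not to tolerate every change, as a 4.3-fold higher number from compound 1 to compound 4 (0.63 log units; beyond the scatter) and a 6.4-fold higher number from compound 3 to compound 4 (0.80 log units; beyond the scatter) are the first steps in this set beyond the scatter, and both run toward weaker inhibition. The sharpest contrast comes from methyl in place of hydrogen on a saturated chain carbon, two bonds along the chain from an oxygen on a saturated carbon: this one change gives a 4.2-fold higher number from compound 2 to compound 4 (0.62 log units; beyond the scatter) and separates compound 4 from compound 2, although compound 2 also carries a hydroxyl and stays within the scatter of compound 1, so the hydroxyl alone does not go with the weaker number. Nothing measured here explains why this methyl makes such a difference.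

The compounds shown leave open whether a longer chain in place of the ethyl groups of 1-ethyl-1-hydroxypropyl would raise the number further or whether the rise ends with compound 4. They also leave open how an amine in place of that hydroxyl would read in this assay on this same core.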